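A few compounds are considered here, and "the series" means these few. Any claim that something is new, unique, unknown or untested is made for them only; others in the source may bear on it.

In a functional assay on MCF7 cells (Homo sapiens) for inhibition, read by CCK-8 assay, with a stated time of 48 h (on this read-out lower numbers stand for stronger inhibition and higher numbers for weaker inhibition), compound 1 `COc1cc(-c2ccnc3cc(-c4ccc(C(C)=O)cc4)nn23)cc(OC)c1OC` gives 5230 nM, the highest number of the three measured. Compound 2 `COc1cc(-c2ccnc3cc(-c4ccc(N(C)C)cc4)nn23)cc(OC)c1OC` gives 44 nM and compound 3 `COc1ccc(-c2cc3nccc(-c4cc(OC)c(OC)c(OC)c4)n3n2)cc1` gives 125 nM. Compound 4 `COc1cc(-c2ccnc3cc(-c4ccc(F)cc4)nn23)cc(OC)c1OC` differs from compound 1 by fluoro in place of acetyl on an aromatic carbon. Among the measured compounds shown here, two measured steps bear on this change, as both also remove the acetyl group: a 120-fold lower number from compound 1 to compound 2 (2.08 log units; beyond the scatter) and a 42-fold lower number from compound 1 to compound 3 (1.62 log units; beyond the scatter). Both are large and point downward, so a lower number for compound 4 is expected, though neither methoxy nor dimethylamino resembles fluoro, and the size is uncertain. For compound 4 the estimated step is a 13-fold lower number from compound 1 to compound 4 (1.12 log units; beyond the scatter). Compound 4 is therefore estimated at 400 nM, with a range from 80 nM to 2000 nM.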

Compound 4, half-maximal inhibitory concentration: 1280 nM
The estimate for compound 4 lay 3.2-fold (0.51 log units) below the measured number; the measured number falls inside the stated range.
By their numbers in this assay, from the lowest: compound 2; then compound 3; then compound 4; then compound 1.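

Replacing the acetyl of compound 1 with fluoro in this assay brings only a modest gain (a 4.1-fold lower number from compound 1 to compound 4 (0.61 log units; beyond the scatter)), so removing the acetyl does not by itself give the much lower numbers of compound 2 and compound 3. The entering group matters at this position, as fluoro falls well short of methoxy (a 10-fold higher number from compound 3 to compound 4 (1.01 log units; beyond the scatter)) and further short of dimethylamino (a 29-fold higher number from compound 2 to compound 4 (1.46 log units; beyond the scatter)). No measurement shown gives a cause for this order. From the compounds shown here alone, it remains open whether a primary amine, a hydroxyl or a longer ethoxy chain here would match compound 2.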